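Swapping octyloxy for phenyl on compound 1

The source may report more compounds than this note shows. Statements on the series, on what has been measured and on what is new or still open speak of the compounds shown alone.

In an ADME assay on U2OS cells (Homo sapiens) for cytotoxicity (on this read-out lower numbers stand for higher toxicity in this test and higher numbers for lower toxicity in this test), compound 1 `CCCCCCCCOc1ccc(C(=O)N/N=C/c2ccc([N+](=O)[O-])o2)cc1` gives > 200000 nM as its result, and that is a limit of the test, not a number.

For the measured compounds named here, compound 2 `O=C(N/N=C/c1ccc([N+](=O)[O-])o1)C1CCCCC1` gives 25400 nM in this assay and so provides the only true number so far.

Compound 3 `O=C(N/N=C/c1ccc([N+](=O)[O-])o1)c1ccc(-c2ccccc2)cc1` has not been measured yet. It keeps the core of compound 1 and carries phenyl in place of octyloxy on an aromatic carbon. The counted change phenyl in place of octyloxy on an aromatic carbon is the only difference, and it lies on a six-membered aromatic ring of carbon only, para to a large group.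

Going by the values given here, no measured pair of compounds differs in just one place, so the expectation rests on thin evidence. Compound 2 at 25400 nM shows that a measurable number can appear in this small set, which is the only reason to expect a move toward lower numbers. The expected step of an at least 4.0-fold lower number from compound 1 to compound 3 (0.60 log units; beyond the scatter) therefore points toward higher toxicity, though its size is uncertain.

For compound 3 the estimate is 50000 nM with an expected range from 12000 nM to 200000 nM in this test.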

Compound 3, half-maximal cytotoxic concentration: 109000 nM
For compound 3 the middle estimate is 2.2-fold (0.34 log units) below the measured one; low and high end bracket the measured number.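

In this assay, phenyl in place of octyloxy on the aromatic carbon gives an at least 1.8-fold lower number from compound 1 to compound 3 (0.26 log units; that floor lies within the scatter), so this change can be read only as a floor, and that floor does not clear the usual scatter of repeated measurements. The true size of the step stays unknown, and the floor is all that can be stated, because the result for compound 1 is a limit and not a number: the limit of > 200000 nM in this assay, at which 1 of the 3 values shown sits.

For the compounds shown here, what is new is that compound 3, at 109000 nM, gives the first true number for a compound that keeps the six-membered aromatic ring of carbon only and carries a large group in this place, which compound 2 could not show.

A single step cannot tell whether the gain of the phenyl ring or the loss of the octyloxy chain with its oxygen matters for the change in this read-out. Going by these compounds, what an amine, a carboxylic acid or a shorter chain on the same aromatic carbon would give remains open, and so does whether any trend exists at this position.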